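Swapping a methylsulfanyl for an amino on a purine nucleoside

The source may hold more compounds than are shown below. What is called first, only, known or untested is meant among the compounds shown, and "the series" means these compounds.

Measured in a functional assay on PHA-Ly cells (Homo sapiens) (on this read-out higher numbers stand for weaker inhibition and lower numbers for stronger inhibition), so far:
- compound 1, `CSc1nc(SC)c2ncn([C@@H]3C[C@@H](O)[C@H](CO)O3)c2n1`: 167 uM
- compound 2, `CNc1nc(Br)nc2c1ncn2[C@@H]1C[C@@H](O)[C@H](CO)O1`: 30 uM

Compound 1 holds the highest number of the two; compound 2 sits at a lower number, and that gap lies beyond the usual scatter. Compound 3, `CSc1nc(N)c2ncn([C@@H]3C[C@@H](O)[C@H](CO)O3)c2n1`, has not been measured. It differs from compound 1 in one place: amino in place of methylsulfanyl on an aromatic carbon. Within the data shown here, no measured pair shows this same exchange, so the size of its effect is unknown. Compound 2, which also carries a nitrogen-bearing group at a comparable position, gives 30 uM, and on that basis a moderate move toward stronger inhibition is expected from compound 1 to compound 3, a 3.7-fold lower number from compound 1 to compound 3 (0.57 log units; beyond the scatter). Compound 3 is estimated at 45 uM, with a likely range of 12 uM to 170 uM.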

Compound 3, concentration for 50% inhibition: 82 uM
Beside the measured number, compound 3's estimate is 1.8-fold (0.26 log units) below it; measured number inside the range.
By their numbers in this assay, from the lowest: compound 2; then compound 3; then compound 1.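

In this assay, the exchange of methylsulfanyl for amino on this aromatic carbon gives a 2.0-fold lower number from compound 1 to compound 3 (0.31 log units; beyond the scatter), a modest step. This shows that the position responds to a change of group, and that the methylsulfanyl there is not required for inhibition in these cells. Nothing available explains why the number falls.

This single step cannot separate the gain of the amino from the loss of the methylsulfanyl. From the compounds shown here alone, how a hydroxyl, a dimethylamino or a longer ethylsulfanyl group would behave at this position remains open.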